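Methoxy on compound 2: expected growth inhibition of compound 3

The compounds below may be only part of what the source reports. "The series", "measured", "known", "first", "only" and "open" are said of these compounds alone.

Of the compounds shown here, two have numbers so far. In a functional assay on PC-3 cells (Homo sapiens) for inhibition, read by sulforhodamine B assay, with a stated time of 48 h, tested at 10 uM (on this read-out lower numbers stand for less inhibition of growth and higher numbers for more inhibition of growth at the one concentration tested), compound 1 (`COc1ccc(-c2nc3sc(-c4ccccc4)cn3n2)cc1`) gives 33% and compound 2 (`Clc1ccc(-c2cn3nc(-c4ccccc4)nc3s2)cc1`) gives 31% at the single concentration tested. Compound 2 therefore stands level with compound 1, the two values lying within the scatter of each other, and neither can be ranked above the other.

Compound 3 (`COc1ccc(-c2nc3sc(-c4ccc(Cl)cc4)cn3n2)cc1`) differs from compound 2 by one change: methoxy in place of hydrogen on an aromatic carbon with methoxy in place of hydrogen on an aromatic carbon, para to a large group. For the measured compounds named here, no two measured compounds differ in one place, so the series offers no measured step for this change. Going by the values given here, the only guide is the closeness of the two existing values, and that is thin evidence. No step beyond the scatter is expected in this assay, and no direction can be favoured with confidence. The estimated step of a number 3 percentage points higher from compound 2 to compound 3 (within the scatter) stays small on that basis. For compound 3 the expected value is 34% with an estimated range from 16% to 52% in this read-out.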

Compound 3, percent growth inhibition at one concentration: 41.9%
Beside the measured number, compound 3's estimate is 7.9 percentage points below it; the range from low to high includes it.
By their numbers in this assay, from the lowest: compounds 2, 1 and 3 (each within the scatter of the next, the first and the last beyond it).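

In this assay, for the compounds shown here, methoxy in place of hydrogen on an aromatic carbon, para to a large group, gives the first step that can be read beyond the scatter: a number 10.9 percentage points higher from compound 2 to compound 3 (beyond the scatter) is a modest gain in growth inhibition at this position, and it is a single step on a single background. Chloro in place of hydrogen on an aromatic carbon gives a number 8.9 percentage points higher from compound 1 to compound 3 (within the scatter) and so does not separate compound 3 from compound 1, which means that in these pairs only the methoxy change registers as a real difference. Nothing available bears on why methoxy has this effect at this position.

From the compounds shown here alone, whether the step belongs to methoxy itself or would also appear with another group at the same place stays open, and an ethoxy chain, a hydroxyl or a dimethylamino group would help to separate these cases. Going by these compounds, it is also open whether the methoxy step holds on a background without the chloro group, and whether it would persist at concentrations other than the one tested.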